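Compound 1 to compound 3: a side-chain exchange

The compounds below may be only part of what the source reports. "The series", "measured", "known", "first", "only" and "open" are said of these compounds alone.

In a functional assay on MGC-803 cells (Homo sapiens) for cytotoxicity, read by MTT assay, with a stated time of 38 h (a higher number here means a weaker inhibitor, a lower number a stronger inhibitor), compound 1 (`COc1cc(OC)c2c(=O)c(OCC(=O)N/N=C/c3ccccc3F)c(-c3cc(OC)c(OC)c(OC)c3)oc2c1`) holds the lower of the two measured numbers at 2780 nM against compound 2 (`COc1cc(OC)c2c(=O)c(OCCCN3CCCC3)c(-c3cc(OC)c(OC)c(OC)c3)oc2c1`) at 32100 nM in the same read-out. Compound 3 (`COc1cc(OC)c2c(=O)c(OCCCCN3CCN(C)CC3)c(-c3cc(OC)c(OC)c(OC)c3)oc2c1`) differs from compound 1 by a group of 10 heavy atoms (8 carbon, 2 nitrogen; one six-membered non-aromatic ring with 2 hetero atoms) in place of a group of 12 heavy atoms (8 carbon, 2 nitrogen, 1 oxygen, 1 fluorine; one six-membered aromatic ring of carbon only), on a saturated chain carbon bound to an oxygen on an aromatic ring with 3-(4-methylpiperazin-1-yl)propyl as the entering group. For the measured compounds named here, the one measured step bearing on this is a 12-fold higher number from compound 1 to compound 2 (1.06 log units; beyond the scatter) and it removes the same group. A higher number is therefore expected, with the estimated step of a 5.0-fold higher number from compound 1 to compound 3 (0.70 log units; beyond the scatter) in this assay and of similar or somewhat smaller size. Compound 3 is expected at 14000 nM with 4000 nM to 45000 nM as its estimated range.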

Compound 3, half-maximal inhibitory concentration: 12200 nM
Estimate against measurement, compound 3: 1.1-fold (0.06 log units) above; the range from low to high includes it.
By their numbers in this assay, from the lowest: compound 1; then compound 3; then compound 2.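

Replacing the group that leaves compound 1 with 3-(4-methylpiperazin-1-yl)propyl again raises the number in this assay, giving a 4.4-fold higher number from compound 1 to compound 3 (0.64 log units; beyond the scatter), so this rise is not confined to the pyrrolidine of compound 2. The two amine side chains also differ from each other at this position, with (4-methylpiperazin-1-yl)methyl in place of pyrrolidin-1-yl giving a 2.6-fold lower number from compound 2 to compound 3 (0.42 log units; beyond the scatter), while compound 1 keeps the lowest number. No measurement shown accounts for either step.

Open, going by these compounds, is whether the ring or the added methyl link carries the step from compound 2. Also open, on these data alone, is how a morpholine ring or a dimethylamino group on the same chain would read.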